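This account rests on a few compounds, and the source may have more. Where it says the series, first, only, none or still open, it means among the compounds named here.

Three compounds share one core and differ only in what hangs from a saturated chain carbon bound to an aromatic nitrogen. In a functional assay on a cell-free system (plasma) for inhibition of platelet-activating factor acetylhydrolase (Homo sapiens), tested at 100 nM (a lower number here means less inhibition, a higher number more inhibition at the concentration tested (going by the name of the read-out)), compound 1 `CCCCCCCCN(C)C(=O)Cn1cc(Cc2cnc(=O)n(C)c2)c(=O)nc1SCc1ccc(F)cc1` gives 55%. Compound 2 `CCCCCCCCN(C)C(=O)Cn1cc(Cc2cnc(=O)n(CC(=O)N3CCOCC3)c2)c(=O)nc1SCc1ccc(F)cc1` gives 64% in this assay, and compound 3 `CCCCCCCCN(C)C(=O)Cn1cc(Cc2cnc(=O)n(CC(=O)N3CCN(C)CC3)c2)c(=O)nc1SCc1ccc(F)cc1` gives 68%. Compound 3 holds the highest of the three numbers, yet its gap to compound 2 lies within the scatter, so no order between those two can be claimed; the step of a number 13 percentage points higher from compound 1 to compound 3 (beyond the scatter) is the only one beyond the scatter, while a number 9 percentage points higher from compound 1 to compound 2 (within the scatter) and a number 4 percentage points higher from compound 2 to compound 3 (within the scatter) are not.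

Compound 4 `CCCCCCCCN(C)C(=O)Cn1cc(Cc2cnc(=O)n(CC(=O)N3CCN(C(C)=O)CC3)c2)c(=O)nc1SCc1ccc(F)cc1` differs from compound 3 by acetyl in place of methyl on an amine nitrogen in a ring. Within the data shown here, the step that bears most on this is the one from compound 2 to compound 3, where one six-membered ring on the carbonyl carbon was swapped for another and the change stayed within the scatter. An alteration further out on that ring is therefore expected to give a step of a number 3 percentage points lower from compound 3 to compound 4 (within the scatter) that stays within the scatter. Compound 4 is estimated at 65%, within 52% to 78%.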

Compound 4, a percentage reported as inhibition, at one concentration (the size of the read-out at that concentration, not a potency): 80%
Compound 4: middle estimate off by 15 percentage points, on the low side; the measured number lies above the stated range.
By their numbers in this assay, from the lowest: compounds 1, 2 and 3 (each within the scatter of the next, the first and the last beyond it); then compound 4.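

The far end of the ring is not a silent place in this assay: acetyl in place of methyl on the amine nitrogen in the ring gives a number 12 percentage points higher from compound 3 to compound 4 (beyond the scatter), although the earlier swap of ring on the carbonyl carbon stayed within the scatter. The 4-acetylpiperazin-1-yl group also separates from morpholin-4-yl, with a number 16 percentage points higher from compound 2 to compound 4 (beyond the scatter), and the full (4-acetylpiperazin-1-yl)carbonyl group gives a number 25 percentage points higher from compound 1 to compound 4 (beyond the scatter), placing compound 4 beyond the scatter of all three other compounds. Nothing available here accounts for this gain.

Acetyl is the only acyl group shown on that nitrogen, and it remains open whether the gain depends on its carbonyl or on its added size. A longer acyl chain such as propanoyl, or a methanesulfonyl group, at this nitrogen would help to separate these two readings.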